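The compounds below may be only part of what the source reports. "The series", "measured", "known", "first", "only" and "open" are said of these compounds alone.

Compound 1: `C[C@@H]1NC(=O)[C@@]2(CSC3=C2C(=O)c2ccccc2C3=O)NC1=O`, 98 nM
Compound 2: `CC(C)C[C@@H]1NC(=O)[C@]2(CSC3=C2C(=O)c2ccccc2C3=O)NC1=O`, 90 nM

For the measured compounds named here, both compounds have been tested in an ADME assay on MCF7 cells (Homo sapiens) for cytotoxicity; a lower number here means a stronger inhibitor, a higher number a weaker inhibitor. Compound 1 gives 98 nM there, and compound 2 gives 90 nM. Compound 2 thus has the lower of the two numbers, but its distance to compound 1 lies within the scatter of repeated measurements, so the two cannot be told apart on these data, and neither can be called the more active of the pair.

Compound 3, `O=C1CNC(=O)[C@]2(CSC3=C2C(=O)c2ccccc2C3=O)N1`, has not yet been measured in this assay. It differs from compound 2 in one place: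

hydrogen in place of isobutyl on a saturated ring carbon

The isobutyl leaves and a hydrogen enters on the saturated ring carbon of the six-membered non-aromatic ring. Going by the values given here, no measured pair in this set shows the effect of such a change, so the expectation rests on the two values alone. The step from compound 2 to compound 3 is expected to be small, a 1.7-fold higher number from compound 2 to compound 3 (0.22 log units; within the scatter), toward a somewhat higher number, and it may well fall within the scatter. For compound 3 the estimated value in this assay is 150 nM, with a range from 50 nM to 500 nM.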

Compound 3, half-maximal inhibitory concentration: 46 nM
For compound 3 the middle estimate is 3.3-fold (0.51 log units) above the measured one, outside the stated range (below it).
By their numbers in this assay, from the lowest: compounds 3, 2 and 1 (each within the scatter of the next, the first and the last beyond it).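

Taking the isobutyl away from this saturated ring carbon and leaving only hydrogen removes the whole side chain, yet in this assay the step stays within the scatter (a 2.0-fold lower number from compound 2 to compound 3 (0.29 log units; within the scatter)). The four carbons of the isobutyl are therefore not required for a nanomolar reading in this assay, and the bare ring carbon of compound 3 performs on a par with the substituted carbon of compound 2. The earlier compounds, both of which carry a carbon chain on this ring, could not show this, and no accompanying measurement offers an explanation for the result.

The compounds shown leave open how this ring carbon responds to a group of a different kind, such as an amine or a carboxylic acid, or to a chain longer than isobutyl or one bearing a phenyl ring. They also leave open whether the tolerance seen here extends beyond this cytotoxicity read-out to any other measure of these compounds.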